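From a Carboxylic Acid to a Methylsulfanyl Group

The source may report more compounds than this note shows. Statements on the series, on what has been measured and on what is new or still open speak of the compounds shown alone.

compound 1, `COC(=O)c1ccc(C#CCCCCC(=O)c2ncc(-c3ccccn3)o2)cc1`: 25 nM
compound 2, `O=C(CCCCC#Cc1ccccn1)c1ncc(-c2ccccn2)o1`: 280 nM
compound 3, `O=C(O)c1ccc(CCCCCCC(=O)c2ncc(-c3ccccn3)o2)cc1`: > 600 nM

Of the compounds shown here, three built on the core of compound 1 have been measured in an assay for inhibition of Fatty-acid amide hydrolase 1 (Rattus norvegicus); on this read-out lower numbers stand for stronger inhibition and higher numbers for weaker inhibition. Compound 1 gives 25 nM and compound 2 gives 280 nM. For compound 3 the read-out is a limit of the assay, > 600 nM. It sits at the limit of > 600 nM in this assay, at which 1 of the 3 values shown sits, so compound 3 stands at the weak end of the three values shown, with no number of its own.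

Compound 4, `CSc1ccc(CCCCCCC(=O)c2ncc(-c3ccccn3)o2)cc1`, has not yet been measured. It differs from compound 3 in one place: methylsulfanyl in place of carboxy on an aromatic carbon. The group that leaves brings one hydrogen-bond donor; the group that enters brings none.

Among the measured compounds, the two without a carboxy group both give numbers in this assay, while compound 3, the only one with a carboxy group, gives only a limit. On that basis the step of an at least 7.5-fold lower number from compound 3 to compound 4 (0.87 log units; beyond the scatter) is expected to be a gain, beyond the usual scatter, though the limit at compound 3 leaves its true size uncertain. Compound 4 is expected to give 80 nM, within a range from 20 nM to 400 nM.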

Compound 4, inhibition constant: 2.5 nM
The estimate for compound 4 lay 32-fold (1.51 log units) above the measured number, outside the stated range (below it).
By their numbers in this assay, from the lowest: compound 4; then compound 1; then compound 2. At a limit, above all of these: compound 3.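

For compound 3 the read-out in this assay is a limit and not a number: the limit of > 600 nM in this assay, at which 1 of the 4 values shown sits. Within the data shown here, until now no measured compound differed from compound 3 in one place, so the weak read-out of the carboxy compound could not be tied to the carboxy group rather than to the rest of the structure. Compound 4 supplies that single change: going from 4-carboxyphenyl to 4-(methylsulfanyl)phenyl, on an aromatic carbon para to a large group and with all else in compound 3 kept, gives an at least 240-fold lower number from compound 3 to compound 4 (2.38 log units; beyond the scatter). This shows that the group at this one position can by itself move the number far beyond the scatter, and that the chain and core of compound 3 are compatible with a low number.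

The compounds shown leave open whether the step comes from the methylsulfanyl group itself or simply from the loss of the carboxy group, a question that a plain hydrogen, a methoxy group or a methylsulfonyl group at the same carbon would address. They also leave open whether methylsulfanyl would act the same way on a chain carrying the triple bond of compound 1.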